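Rearranging the dichlorophenyl group on a shared core

The compounds below may be only part of what the source reports. "The series", "measured", "known", "first", "only" and "open" are said of these compounds alone.

In a functional assay on K562 cells (Homo sapiens) for cytotoxicity, read by MTT assay, with a stated time of 24 h (a lower number here means a stronger inhibitor, a higher number a weaker inhibitor), compound 1 `CN1C/C(=C\c2cccc([N+](=O)[O-])c2)C(=O)/C(=C/c2ccccc2F)C1` gives 3890 nM and compound 2 `CN1C/C(=C\c2cccc([N+](=O)[O-])c2)C(=O)/C(=C/c2ccc(Cl)cc2Cl)C1` gives 12400 nM, the higher of the two numbers. Compound 3 `CN1C/C(=C\c2cccc([N+](=O)[O-])c2)C(=O)/C(=C/c2ccc(Cl)c(Cl)c2)C1` awaits measurement and differs from compound 2 by 3,4-dichlorophenyl in place of 2,4-dichlorophenyl on a double-bonded chain carbon bound to a double-bonded ring carbon. Among the compounds with values here, the only measured step at this place is a 3.2-fold higher number from compound 1 to compound 2 (0.50 log units; beyond the scatter), which shows that the number can move modestly here but gives no direction for this exchange. In this assay, no step beyond the scatter is therefore expected, with a slight lean toward a lower number. The estimated change is a 1.6-fold lower number from compound 2 to compound 3 (0.19 log units; within the scatter). For compound 3 the expected value is 8000 nM, with an estimated range of 2500 nM to 22000 nM.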

Compound 3, half-maximal inhibitory concentration: 15500 nM
Estimate against measurement, compound 3: 1.9-fold (0.29 log units) below, within the range that was stated.
By their numbers in this assay, from the lowest: compound 1; then compounds 2 and 3 (each within the scatter of the next).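

In this assay, the exchange of 2,4-dichlorophenyl for 3,4-dichlorophenyl gives a 1.3-fold higher number from compound 2 to compound 3 (0.10 log units; within the scatter), so these two arrangements of the chlorines are not told apart here. The 3,4-dichlorophenyl group also gives a 4.0-fold higher number from compound 1 to compound 3 (0.60 log units; beyond the scatter), so both dichlorophenyl compounds now stand apart from the 2-fluorophenyl compound. No supporting measurement is available to explain this result. The compounds shown leave open how a single chlorine, a methoxy group or an amine on this phenyl ring would compare, and whether the pattern would hold with an amine in place of the nitro group.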